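The source may hold more compounds than are shown below. What is called first, only, known or untested is meant among the compounds shown, and "the series" means these compounds.

Measured so far in an assay on HEK293 cells for positive allosteric modulation of metabotropic glutamate receptor 5 (Homo sapiens), read by FLIPR, with a stated time of 1 h; on this read-out lower numbers stand for an effect already at smaller amounts and higher numbers for an effect only at larger amounts of compound:
- compound 1 `O=C1c2sc(C#Cc3ccccc3)nc2CN1C1CC1` gives > 10000 nM, a limit of the assay and not a number
- compound 2 `CC(=O)N1CCc2nc(C#Cc3ccccc3)sc2C1` gives > 10000 nM, likewise a limit of the assay and not a number
- compound 3 `O=C(C1CC(F)(F)C1)N1CCc2nc(C#Cc3cccc(F)c3)sc2C1` gives 2.5 nM

Compound 2 therefore stands at the limit and nowhere else on the numbers shown; it is one of the two compounds described by the limit of > 10000 nM in this assay, at which 2 of the 3 values shown sit. Among the measured compounds shown here, compound 3 is the only compound of the three with a number, and since compound 3 differs from compound 2 in more than one place, its value and that of compound 2 can only be set side by side, not read as a single step.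

The step of interest leads from compound 2 to compound 4 `O=C(c1cccc(Cl)c1)N1CCc2nc(C#Cc3ccccc3)sc2C1`. Its content is 3-chlorophenyl in place of methyl on a carbonyl carbon. For the measured compounds named here, no measured step in this set shares this change, so the expectation rests on the pattern that the acetyl compound 2 sits at the limit while the compound carrying a larger amide, compound 3, gives a low number. In this assay the step from compound 2 to compound 4 is expected to be large and towards smaller amounts, an at least 160-fold lower number from compound 2 to compound 4 (2.22 log units; beyond the scatter), with the reservation that a limit start makes its exact size uncertain. Compound 4 is estimated to give 60 nM, with a range from 6 nM to 600 nM.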

Compound 4, half-maximal effective concentration: 8.7 nM
The estimate for compound 4 lay 6.9-fold (0.84 log units) above the measured number, and the stated range covers the measured number.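

an at least 1100-fold lower number from compound 2 to compound 4 (3.06 log units; beyond the scatter) in this assay is the only single-place step shown, with 3-chlorophenyl in place of methyl on a carbonyl carbon. The comparison of compound 2 with compound 3 involved more than one place, whereas here the rest of the structure stays fixed, so this change alone separates a limit from a low number. Compound 2 gives > 10000 nM, a limit of the assay and not a number, so the step has a bound but no exact size: the limit of > 10000 nM in this assay, at which 2 of the 4 values shown sit.

On these data alone, whether the chlorine is needed remains open, as does how an unsubstituted phenyl, a pyridine or a simple amine on the same carbonyl carbon would read. Compound 3 and compound 4 differ in more than one place, so their values can only be set side by side.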